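Chain length at the aromatic nitrogen: propyl to butyl

The source may hold more compounds than are shown below. What is called first, only, known or untested is meant among the compounds shown, and "the series" means these compounds.

Compound 1 `CCCn1ncnc1-c1ccccc1NCC1=NCCN1` carries a propyl chain on an aromatic nitrogen of the shared core. Among the compounds with values here, in a functional assay with Alpha-1D adrenergic receptor (Homo sapiens) as the target, read by calcium flux (on this read-out higher numbers stand for larger maximal responses and lower numbers for smaller maximal responses), compound 1 gives 57%, the highest of the three numbers measured so far. Within the data shown here, compound 2 `CCn1ncnc1-c1ccccc1NCC1=NCCN1` gives 55% in this assay; the single step between the two, a number 2 percentage points lower from compound 1 to compound 2 (within the scatter), is hydrogen in place of methyl on a saturated chain carbon, two bonds along the chain from an aromatic nitrogen, and it leaves the maximal response where it was. Compound 3 `Cc1n[nH]c(-c2ccccc2NCC2=NCCN2)n1` gives 0%; it differs from compound 1 in more than one place, so its gap to compound 1 says nothing about the chain by itself.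

Compound 4 `CCCCn1ncnc1-c1ccccc1NCC1=NCCN1` is not yet measured. It differs from compound 1 by methyl in place of hydrogen on a saturated chain carbon, three bonds along the chain from an aromatic nitrogen, so the chain grows by one carbon in the direction opposite to the shortening seen in a number 2 percentage points lower from compound 1 to compound 2 (within the scatter). Among the measured compounds shown here, that is the only measured step that bears on the change, and it is within the scatter. No step beyond the scatter is therefore expected in this assay, and the estimated step is a number 1 percentage points lower from compound 1 to compound 4 (within the scatter). For compound 4 the expected maximal response is 56%, with a range of 40% to 72%.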

Compound 4, largest response reached (reported as maximal response), in percent of the reference or control that the assay uses: 66%
The estimate for compound 4 lay 10 percentage points below the measured number; measured number inside the range.
By their numbers in this assay, from the lowest: compound 3; then compounds 2, 1 and 4 (each within the scatter of the next, the first and the last beyond it).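

In this assay, the change from propyl to butyl gives a number 9 percentage points higher from compound 1 to compound 4 (within the scatter) and is not resolved when taken alone. Read from the ethyl chain, the same direction of change gives a number 11 percentage points higher from compound 2 to compound 4 (beyond the scatter) and is the first step at this position to pass the scatter, though only a modest one. Across the ethyl, propyl and butyl chains, the numbers therefore show no loss of maximal response as the chain grows, and only the full span from ethyl to butyl separates two compounds, while nothing available here accounts for that difference.

Going by these compounds, whether a pentyl chain, a branched isobutyl chain, a cyclopropylmethyl group or a chain ending in an amine on the aromatic nitrogen would extend this trend, hold it or reverse it remains open. Compound 3 differs from the other compounds in more than one place, so its low number cannot yet be assigned to any single change.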